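Stereocentre inversion at the ring carbon of compound 1

The source may report more compounds than this note shows. Statements on the series, on what has been measured and on what is new or still open speak of the compounds shown alone.

Measured so far:
compound 1, `N=C(N)NCCC[C@H](N)C(=O)NCC(=O)N[C@@H](CC(=O)O)C(=O)N[C@@H](CSCc1cn(CCO[C@H]2O[C@H](CF)[C@@H](O)[C@H](O)[C@@H]2O)nn1)C(=O)O` — 23500 nM
compound 2, `NC(N)=NCCC[C@H](N)C(=O)NCC(=O)N[C@@H](CC(=O)O)C(=O)N[C@@H](CS)C(=O)O` — 322000 nM

Both numbers come from a functional assay on a cell-free system (Platelet, plasma, Homo sapiens) for inhibition, with a stated time of 10 min, at 37 degrees C; on this read-out higher numbers stand for weaker inhibition and lower numbers for stronger inhibition. Compound 1 gives 23500 nM in this assay; compound 2 gives 322000 nM. Of the two, compound 1 carries the lower number, and the gap to compound 2 lies beyond the scatter of repeat measurements, so compound 1 is the stronger inhibitor of the pair. Within the data shown here, no single-change step between the two measured compounds is available, and nothing in the data speaks to how the drawn configuration of a ring carbon bears on the read-out.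

The unmeasured compound is compound 3, `N=C(N)NCCC[C@H](N)C(=O)NCC(=O)N[C@@H](CC(=O)O)C(=O)N[C@@H](CSCc1cn(CCO[C@H]2O[C@H](CF)[C@@H](O)[C@H](O)[C@H]2O)nn1)C(=O)O`. Its relation to compound 1 is the two compounds have the same atoms and bonds; at least one stereo element is drawn with a configuration in one of them and without one in the other: 1 of 9 stereo elements differ; a stereocentre at a saturated ring carbon is drawn S in compound 1 and R in compound 3. Atoms and bonds are unchanged; only one of the nine stereo elements is drawn the other way.

With no step of this kind in hand, the step from compound 1 to compound 3 is expected to be small and is estimated as a 1.5-fold higher number from compound 1 to compound 3 (0.17 log units; within the scatter), leaning if anything toward a weaker number. Compound 3 is therefore estimated at 35000 nM, with a range from 10000 nM to 120000 nM, still well below the number of compound 2.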

Compound 3, half-maximal inhibitory concentration: 26000 nM
The estimate for compound 3 lay 1.3-fold (0.13 log units) above the measured number; the range from low to high includes it.
By their numbers in this assay, from the lowest: compounds 1 and 3 (each within the scatter of the next); then compound 2.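

In this assay, drawing the saturated ring carbon R instead of S gives a 1.1-fold higher number from compound 1 to compound 3 (0.04 log units; within the scatter), so the two configurations at this carbon cannot be told apart on this read-out. Among these compounds, this is the first single-change step, and it gives this stereocentre a direct reading that the earlier compounds could not: in this setting, the configuration at this one carbon does not register as a difference beyond the scatter. The step comes with one structural caveat, which limits how firmly it can be read as a clean exchange of one configuration for the other: the fact that one of compounds 1 and 3 is drawn with a defined configuration and the other without, at the place where they differ

Open, from the compounds shown here alone, is whether the same holds at the other stereocentres of the ring, since this step speaks for one of the nine stereo elements only. Also open, going by these compounds, is how the number in this assay would respond to a hydroxymethyl group in place of the fluoromethyl group, or to a longer chain between the triazole and the ring.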